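A few compounds are considered here, and "the series" means these few. Any claim that something is new, unique, unknown or untested is made for them only; others in the source may bear on it.

Working notes on the series. Compound 1 `C[C@H](CF)OC(=O)N1CCC(O[C@H]2CC[C@H](Oc3cnc(S(C)(=O)=O)cn3)CC2)CC1` and compound 2 `CS(=O)(=O)c1cnc(O[C@H]2CC[C@H](OC3CCN(C(=O)C4(C(F)(F)F)CC4)CC3)CC2)cn1` share one core and differ only in the group on the carbonyl carbon. In a functional assay on isolated protein for agonist activity at Glucose-dependent insulinotropic receptor (Rattus norvegicus), read by HTRF and cAMP accumulation (on this read-out higher numbers stand for larger maximal responses and lower numbers for smaller maximal responses), compound 1 gives 115%, and in this assay compound 2 gives 140%. For the measured compounds named here, the single measured step, a number 25 percentage points higher from compound 1 to compound 2 (beyond the scatter), leaves compound 2 as the highest of the two numbers in this assay, with compound 1 as its nearest neighbour and lower by a margin beyond the scatter.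

Compound 3 `CS(=O)(=O)c1cnc(O[C@H]2CC[C@H](OC3CCN(CC4(C(F)(F)F)CCC4)CC3)CC2)cn1` is the next member. Its change from compound 2 is (1-(trifluoromethyl)cyclobutyl)methyl in place of (1-(trifluoromethyl)cyclopropyl)carbonyl on an amine nitrogen in a ring. Going by the values given here, the step from compound 1 to compound 2 bears on it only loosely: that step kept the carbonyl and swapped the group on it, whereas here the carbonyl itself leaves and an alkyl group enters on the ring nitrogen, a kind of exchange no measured pair covers. The expectation for compound 3 is therefore a move of a number 20 percentage points lower from compound 2 to compound 3 (beyond the scatter) in this assay, downward if anything, with wide uncertainty. Compound 3 is estimated at 120%, within a range from 85% to 150%.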

Compound 3, largest response reached (Emax), in percent of the reference or control that the assay uses: 99%
Estimate against measurement, compound 3: 21 percentage points above; low and high end bracket the measured number.
By their numbers in this assay, from the lowest: compound 3; then compound 1; then compound 2.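

In this assay, for the compounds shown here, the substituent on the amine nitrogen in the ring had so far been seen to move only upward; the exchange of (1-(trifluoromethyl)cyclopropyl)carbonyl for (1-(trifluoromethyl)cyclobutyl)methyl gives a number 41 percentage points lower from compound 2 to compound 3 (beyond the scatter), so this position can also lower the maximal response, and by a large step. Going by these compounds alone, compound 3 also falls short of the other carbonyl-bearing group, with a number 16 percentage points lower from compound 1 to compound 3 (beyond the scatter), which places the one compound without a carbonyl on that nitrogen under both compounds that have one, a pattern that rests on these three compounds alone and that none of them goes against. Nothing available on these compounds offers an explanation for the lower maximal response of compound 3.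

The step from compound 2 to compound 3 changes two things at once, the carbonyl and the size of the carbon ring, so the compounds shown do not tell which of the two accounts for the change. On these data alone, a (1-(trifluoromethyl)cyclopropyl)methyl group or a (1-(trifluoromethyl)cyclobutyl)carbonyl group on the same nitrogen would separate them, and how either would read remains open.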